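Compound 3: a smaller group on the carbonyl

A few compounds are considered here, and "the series" means these few. Any claim that something is new, unique, unknown or untested is made for them only; others in the source may bear on it.

Compound 1 `CCCCCCCC/C=C\CCCCCCCCOC[C@@H]1CCCN1[S+]([O-])c1ccc(C)cc1` gives > 100000 nM
Compound 2 `CCCCCCCC/C=C\CCCCCCCCOC[C@@H]1CCCN1C(=O)[C@@H]1CCCN1` gives 4300 nM

Both results come from a functional assay on BXPC-3 cells (Homo sapiens) for inhibition, read by XTT assay, with a stated time of 72 h; on this read-out lower numbers stand for stronger inhibition and higher numbers for weaker inhibition. Compound 1 gives only a limit of the assay and not a true number, > 100000 nM. Within the data shown here, that leaves compound 2 with the only true number so far, 4300 nM, so there is no second firm value to compare it with.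

Among the measured compounds shown here, the one measured step, an at least 23-fold lower number from compound 1 to compound 2 (1.36 log units; beyond the scatter), is large, and its size is itself a bound, as one end is a limit. Compound 3 `CCCCCCCC/C=C\CCCCCCCCOC[C@@H]1CCCN1C(=O)CN` is the next structure. The change is aminomethyl in place of pyrrolidin-2-yl on a carbonyl carbon, which means aminomethyl in place of pyrrolidin-2-yl on a carbonyl carbon, and the carbonyl stays.

That earlier step exchanged the whole group on an amine nitrogen in a ring, whereas this change alters only part of the group that compound 2 carries. It is therefore a weak guide, and a step of similar size is not expected. In this assay the best expectation is no shift beyond the scatter, with a slight lean towards a higher number. The expected change is a 1.3-fold higher number from compound 2 to compound 3 (0.11 log units; within the scatter). For compound 3 the estimated value is 5500 nM, with an expected range from 1500 nM to 20000 nM.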

Compound 3, half-maximal inhibitory concentration: 5300 nM
Compound 3: middle estimate off by 1.0-fold (0.02 log units), on the high side; low and high end bracket the measured number.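

In this assay, aminomethyl in place of pyrrolidin-2-yl on a carbonyl carbon gives a 1.2-fold higher number from compound 2 to compound 3 (0.09 log units; within the scatter), so the two compounds cannot be told apart, even though the group loses its ring and defined stereocentre. The much smaller (aminomethyl)carbonyl group also gives an at least 18-fold lower number from compound 1 to compound 3 (1.27 log units; beyond the scatter), which shows that the large step seen earlier does not depend on having the pyrrolidin-2-yl ring in the group. The size of that step is only a bound because compound 1 sits at a limit of the assay and not at a true number: the limit of > 100000 nM in this assay, at which 1 of the 3 values shown sits.

Going by these compounds, what remains open is whether the amine in this group matters at all, since both compound 2 and compound 3 carry one, and a plain acetyl group or a carboxylic acid in its place would answer that, while a longer chain such as 3-aminopropyl would show how far the amine can move. On these data alone, all three compounds also share the same long unsaturated chain, so the effect of a shorter chain on this core is unknown.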